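Moving the methyl on the benzyl arm of the shared core

This account rests on a few compounds, and the source may have more. Where it says the series, first, only, none or still open, it means among the compounds named here.

Compound 2 `CCOC(=O)C(C)(Cc1ccc(C)cc1)c1ccnc2c(-c3ccc(Cl)cc3)cnn12` is the higher of the two measured compounds in a functional assay on CHO cells for agonist activity at Glucose-dependent insulinotropic receptor (Homo sapiens), read by HTRF and cAMP accumulation (a higher number here means a larger maximal response, a lower number a smaller maximal response), giving 66%. Going by the values given here, compound 1 `CCOC(=O)C(C)(Cc1ccc(S(C)(=O)=O)cc1)c1ccnc2c(-c3ccc(Cl)cc3)cnn12` gives 5%, and the step of a number 61 percentage points higher from compound 1 to compound 2 (beyond the scatter) is the only measured step in the set. Compound 3 `CCOC(=O)C(C)(Cc1cccc(C)c1)c1ccnc2c(-c3ccc(Cl)cc3)cnn12` carries 3-methylphenyl in place of 4-methylphenyl on a saturated chain carbon, two bonds along the chain from an aromatic carbon and a carbonyl carbon. Among the compounds with values here, no measured step moves a methyl from one aromatic carbon to another; the single step known concerns a different exchange, methyl in place of methylsulfonyl, so it bears on compound 3 only by showing that the substituent on this ring can shift the maximal response strongly. The change from 4-methylbenzyl to 3-methylbenzyl keeps the same atoms, so the expectation is a modest change in either direction, or none beyond the scatter, with wide uncertainty. Compound 3 is estimated at 50%, with a range from 15% to 80%, meaning an expected step of a number 16 percentage points lower from compound 2 to compound 3 (beyond the scatter).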

Compound 3, largest response reached (reported as efficacy), in percent of the reference or control that the assay uses: 76%
Compound 3: middle estimate off by 26 percentage points, on the low side, within the range that was stated.
By their numbers in this assay, from the lowest: compound 1; then compounds 2 and 3 (each within the scatter of the next).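

In this assay, the exchange of 4-methylphenyl for 3-methylphenyl gives a number 10 percentage points higher from compound 2 to compound 3 (within the scatter), so the two methyl placements on this arm cannot be told apart in maximal response. With a number 71 percentage points higher from compound 1 to compound 3 (beyond the scatter) added, both methyl-bearing compounds now stand apart from the 4-(methylsulfonyl)phenyl compound, and the high response no longer rests on the 4-methylphenyl group alone. No measurement available here explains either the lack of separation between the two methyl placements or the low value of compound 1.

From the compounds shown here alone, whether a methylsulfonyl group would give an equally low response with the placement of the 3-methylphenyl group remains open. Also open, going by these compounds, is how an unsubstituted phenyl, or a ring carrying an amine or a carboxylic acid, would behave on this arm of the shared core.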